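The source may report more compounds than this note shows. Statements on the series, on what has been measured and on what is new or still open speak of the compounds shown alone.

In an in vitro ADME assay on microsomes from liver (Homo sapiens) for metabolic stability, read by LC-MS (a higher number here means that the compound lasts longer, a lower number that the compound disappears faster), compound 1 (`N#Cc1ccccc1Cn1c(N2CCC[C@@H](N)C2)ncc(-c2ccoc2)c1=O`) gives 0.933 h, and compound 2 (`N#Cc1ccccc1Cn1c(N2CCC[C@@H](N)C2)cc(=O)[nH]c1=O`) gives 2.15 h. Compound 3 (`N[C@@H]1CCCN(c2cc(=O)[nH]c(=O)n2Cc2ccccc2Br)C1`) gives > 3.33 h, which is a limit of the assay and not a number. This places compound 3 at the limit of > 3.33 h in this assay, at which 1 of the 3 values shown sits, so its true half-life is not known.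

Compound 4 (`Cn1c(=O)cc(N2CCC[C@@H](N)C2)n(Cc2ccccc2Br)c1=O`) is made from compound 3 by one small change: a methyl in place of hydrogen on an aromatic nitrogen, para to a 3-aminopiperidin-1-yl group and meta to a 2-bromobenzyl group (methyl in place of hydrogen on an aromatic nitrogen).

Only one measured step links two of these compounds by a single change: an at least 1.5-fold higher number from compound 2 to compound 3 (0.19 log units; that floor lies within the scatter). That step concerns a different place, with bromo in place of cyano on an aromatic carbon, so it offers no size for adding a methyl on the nitrogen. Among the measured compounds shown here, no measured pair shows this change. The expected step in this assay is therefore none beyond the scatter, with no favoured direction, and is estimated as a number no higher from compound 3 to compound 4 (the limit leaves the size open). The half-life expected for compound 4 is 3.3 h. The estimated range for compound 4 runs from 1.5 h to 7 h.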

Compound 4, half-life: > 3.33 h
Compound 4 ended at the assay's limit; the forecaster's own chance of this, stated with the estimate: 45%; at least 1.0-fold (0.00 log units) between middle value and limit.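

Compound 3 and compound 4 both sit at the same limit of the assay, which is a limit and not a number, so no step can be read between them: the limit of > 3.33 h in this assay, at which 2 of the 4 values shown sit. The compounds shown leave open how long compound 3 and compound 4 really last in this assay, and whether methyl in place of hydrogen on an aromatic nitrogen shifts the half-life at all.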